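Benzoyl for Vinyl on a Sulfur-Bound Chain

The source may report more compounds than this note shows. Statements on the series, on what has been measured and on what is new or still open speak of the compounds shown alone.

Compound 1 `CCc1nnc(SC)n1N1C(=O)c2ccccc2C1=O` and compound 2 `C=CCSc1nnc(-c2cc(OC)c(OC)c(OC)c2)n1N1C(=O)c2ccccc2C1=O` were both tested in a functional assay on A549 cells (Homo sapiens) for cytotoxicity, read by MTT assay, with a stated time of 48 h; a higher number here means a weaker inhibitor, a lower number a stronger inhibitor. In this assay compound 1 gives only a limit of the assay, > 200000 nM. Compound 2 likewise gives only a limit, > 200000 nM. Both values sit at the edge of what the assay reports, as the limit of > 200000 nM in this assay, at which 2 of the 2 values shown sit, shows. Compound 3 `COc1cc(-c2nnc(SCC(=O)c3ccccc3)n2N2C(=O)c3ccccc3C2=O)cc(OC)c1OC` differs from compound 2 by benzoyl in place of vinyl on a saturated chain carbon bound to a sulfur. Among the compounds with values here, no measured pair shows what this change does, so no direction is known. Compound 3 is expected to show a number no higher from compound 2 to compound 3 (the limit leaves the size open), essentially no step beyond the scatter. Compound 3 is estimated at 200000 nM, ranging from 40000 nM to 600000 nM.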

Compound 3, half-maximal inhibitory concentration: > 200000 nM
Compound 3: only a limit was reported; the forecaster's own chance of this, stated with the estimate: 65%; the middle value lies on the limit itself.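

Within the data shown here, compound 3 also gives only a limit of the assay (> 200000 nM), so no step from compound 2 to compound 3 can be read. The compounds shown leave open what benzoyl in place of vinyl does, and whether any compound of this kind gives a readable number in this assay at all.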